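A Sulfonamide Series Against HSP60/HSP10: One Expected Step

The compounds below may be only part of what the source reports. "The series", "measured", "known", "first", "only" and "open" are said of these compounds alone.

Compound 1 `N#Cc1ccc(S(=O)(=O)Nc2ccc(-c3nc4cc(NS(=O)(=O)c5ccc(C#N)cc5)ccc4o3)cc2)cc1`: 49000 nM
Compound 2 `COc1ccc(S(=O)(=O)Nc2ccc(-c3nc4ccccc4o3)cc2)cc1`: > 100000 nM
Compound 3 `O=S(=O)(Nc1ccc2oc(-c3ccccc3)nc2c1)c1ccccc1C(F)(F)F`: > 100000 nM

These three values come from an assay on cells for inhibition of HSP60/HSP10 (Homo sapiens), with a stated time of 60 min; a lower number here means a stronger inhibitor, a higher number a weaker inhibitor. For compound 2 the figure is a limit of the assay, not a number. The same is true of compound 3. Compound 2 therefore stands at the limit of > 100000 nM in this assay, at which 2 of the 3 values shown sit, and compound 1 is the only one of the three with a numerical result.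

Compound 4 `O=S(=O)(Nc1ccc(-c2nc3ccccc3o2)cc1)c1ccccc1Cl` has not yet been tested. It differs from compound 2 in one place: 2-chlorophenyl in place of 4-methoxyphenyl on a sulfonyl sulfur. Within the data shown here, no two measured compounds differ in a single place, so no measured step guides this change. Given the limit of > 100000 nM in this assay, at which 2 of the 3 values shown sit, for compound 2, no step beyond the scatter in this assay is expected in either direction. Compound 4 is expected at 100000 nM, between 40000 nM and 300000 nM. The estimated step is a number no higher from compound 2 to compound 4 (the limit leaves the size open).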

Compound 4, half-maximal inhibitory concentration: > 100000 nM
Compound 4: only a limit was reported (the forecaster's own chance of this, stated with the estimate: 65%); the middle value sits exactly at the limit.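

In this assay compound 4 gives > 100000 nM as a limit and not a number. Compound 2 also stands at a limit, and no step can be read between compound 2 and compound 4. The compounds shown leave open whether 2-chlorophenyl in place of 4-methoxyphenyl on a sulfonyl sulfur changes inhibition at all.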